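Swapping pyrrolidin-1-yl for ethyl on the side chain

The source may report more compounds than this note shows. Statements on the series, on what has been measured and on what is new or still open speak of the compounds shown alone.

Results so far in a functional assay on HeLa cells (Homo sapiens) for antiproliferative activity, read by MTT assay, with a stated time of 48 h (on this read-out higher numbers stand for weaker inhibition and lower numbers for stronger inhibition), are these:
- compound 1 `CCN(CC)CCn1c(N)c(-c2nc3ccccc3[nH]2)c2nc(C#N)c(C#N)nc21` with 11600 nM measured
- compound 2 `N#Cc1nc2c(-c3nc4ccccc4[nH]3)c(N)n(CCN3CCCC3)c2nc1C#N` with > 50000 nM as a limit
- compound 3 `CN(C)CCCn1c(N)c(-c2nc3ccccc3[nH]2)c2nc(C#N)c(C#N)nc21` with 25900 nM measured

Compound 2 stands at > 50000 nM in this assay, which is a limit of the assay and not a number. Compound 4 `CCCCn1c(N)c(-c2nc3ccccc3[nH]2)c2nc(C#N)c(C#N)nc21` is still unmeasured, and it differs from compound 2 in one place ethyl in place of pyrrolidin-1-yl on a saturated chain carbon, two bonds along the chain from an aromatic nitrogen so that its side chain is butyl.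

Three measured steps changed this same place. The clearest is an at least 4.3-fold higher number from compound 1 to compound 2 (0.63 log units; beyond the scatter), and it goes beyond the scatter. Another is a 2.2-fold higher number from compound 1 to compound 3 (0.35 log units; beyond the scatter), also beyond the scatter. The third is an at least 1.9-fold lower number from compound 2 to compound 3 (0.28 log units; that floor lies within the scatter), and its floor lies within the scatter. Among the measured compounds shown here, no measured compound has a side chain without nitrogen, so these steps guide the estimate only loosely. Compound 1 and compound 3 both gave real numbers, so a modest move to a lower number is expected. The expected size is an at least 2.0-fold lower number from compound 2 to compound 4 (0.30 log units; that floor lies within the scatter), and this remains an estimate. For compound 4 the expected value is 25000 nM, with an estimated range from 8000 nM to 70000 nM.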

Compound 4, half-maximal inhibitory concentration: > 50000 nM
Compound 4: only a limit was reported; the forecaster's own chance of this, stated with the estimate: 30%; middle value at least 2.0-fold (0.30 log units) from the limit.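

In this assay, putting ethyl in place of diethylamino gives an at least 4.3-fold higher number from compound 1 to compound 4 (0.63 log units; beyond the scatter), so at this position the butyl side chain, which carries no nitrogen, does not keep the measurable activity of the diethylamino chain. The step of an at least 1.9-fold higher number from compound 3 to compound 4 (0.28 log units; that floor lies within the scatter) points the same way, but its floor lies within the scatter, so it is weaker support. Compound 2 keeps a nitrogen in its side chain yet reads the same as compound 4, so a nitrogen alone is not enough here; both values are limits of the assay and not numbers, and the step between these two cannot be read: the limit of > 50000 nM in this assay, at which 2 of the 4 values shown sit.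

As far as these compounds go, how compound 2 and compound 4 truly rank therefore stays open. Also open, from the compounds shown here alone, is whether a side chain ending in a primary amine or a hydroxyl group, or a longer chain carrying diethylamino, would match compound 1.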